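A few compounds are considered here, and "the series" means these few. Any claim that something is new, unique, unknown or untested is made for them only; others in the source may bear on it.

The measurements in a functional assay on A549 cells (Homo sapiens) for cytotoxicity, read by MTT assay, with a stated time of 48 h (on this read-out lower numbers stand for an effect already at smaller amounts and higher numbers for an effect only at larger amounts of compound), so far:

Compound 1 `Cc1c(O)c(=O)ccn1CC(=O)N/N=C1\C(=O)N(CC(=O)Nc2ccc(Br)cc2)c2ccccc21`: 29300 nM
Compound 2 `Cc1c(O)c(=O)ccn1CC(=O)N/N=C1\C(=O)N(CC(=O)Nc2ccc(Cl)cc2)c2ccccc21`: 28300 nM

Compound 2 holds the lowest of the two numbers in this assay, but its nearest neighbour is compound 1, and the gap between them is within the scatter, so no order between the two is claimed. For the measured compounds named here, the single measured step, a 1.0-fold lower number from compound 1 to compound 2 (0.02 log units; within the scatter), puts chloro in place of bromo on the aromatic carbon and changes nothing beyond the scatter.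

Compound 3 `Cc1ccc(NC(=O)CN2C(=O)/C(=N\NC(=O)Cn3ccc(=O)c(O)c3C)c3ccccc32)cc1` is not yet measured. It differs from compound 2 in one place: methyl in place of chloro on an aromatic carbon. Going by the values given here, the only measured step that bears on this change is the halogen swap at the same position, which was within the scatter; it shows that this position tolerated one small exchange without effect, but a methyl for chloro is a different kind of exchange, and no measured pair tests it directly. The expectation for compound 3 is therefore no step beyond the scatter, a 1.1-fold higher number from compound 2 to compound 3 (0.03 log units; within the scatter). Compound 3 is estimated at 30000 nM, with a range from 12000 nM to 75000 nM.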

Compound 3, half-maximal effective concentration: 47500 nM
The estimate for compound 3 lay 1.6-fold (0.20 log units) below the measured number; measured number inside the range.
By their numbers in this assay, from the lowest: compounds 2, 1 and 3 (each within the scatter of the next).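

Compound 3 carries the exchange at this place beyond the halogens: on the aromatic carbon para to a large group, methyl now stands where the earlier pair held only bromo or chloro, and in this assay this gives a 1.7-fold higher number from compound 2 to compound 3 (0.22 log units; within the scatter) and a 1.6-fold higher number from compound 1 to compound 3 (0.21 log units; within the scatter). The tolerance seen so far for a swap of one halogen for another therefore also covers the change from 4-chlorophenyl to 4-methylphenyl, so the three compounds cannot be put in any order, and a carbon group at this place reads the same as a halogen within the scatter. Nothing at hand bears on what lies behind these numbers.

The compounds shown leave open whether this tolerance lasts for groups of another kind or size at the same place, such as an amine, a carboxylic acid, a methoxy group or a longer chain, as chloro and methyl each count only 1 heavy atom. They also leave open whether any change elsewhere on the shared core, rather than on this aromatic ring, would move the number beyond the scatter.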